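Working notes: a second chloro on the shared core

The source may hold more compounds than are shown below. What is called first, only, known or untested is meant among the compounds shown, and "the series" means these compounds.

The series holds three measured compounds and one open one. Compound 1 `ClCc1ccc(Cn2cnc3c(Cl)ncnc32)cc1` was taken into a functional assay on HT-29 cells (Homo sapiens) for cytotoxicity, read by sulforhodamine B assay, with a stated time of 48 h (a higher number here means that more compound is tolerated, a lower number that less compound is tolerated), but no number came back, its entry reading "not determined" (no result reported). Compound 3 `Nc1nc(Cl)c2ncn(Cc3cccc(CCl)c3)c2n1` gives 64600 nM in this assay. Compound 2 `ClCc1ccccc1Cn1cnc2ncnc(Cl)c21` reaches only the limit of this assay, recorded as > 100000 nM, which is a limit of the assay and not a number. Compound 2 therefore stands at the limit (the limit of > 100000 nM in this assay, at which 1 of the 3 values shown sits), and against compound 3 the two entries show only a limit beside a number, so no ordering beyond that is claimed.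

Compound 4 `ClCc1ccccc1Cn1cnc2nc(Cl)nc(Cl)c21` has not yet been measured. Relative to compound 2 the change is chloro in place of hydrogen on an aromatic carbon. Among the compounds with values here, no pair of measured compounds that differ in one place is available, so no measured step guides the expectation. In this assay the step expected is a number no higher from compound 2 to compound 4 (the limit leaves the size open), taken to be none beyond the scatter. Compound 4 is estimated to sit at 100000 nM in this assay, with a range from 35000 nM to 300000 nM, and with a fair chance that again only a limit is reported.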

Compound 4, concentration lethal to 50% of the cells: > 100000 nM
Compound 4: only a limit was reported; the forecaster's own chance of this, stated with the estimate: 60%; the middle value sits exactly at the limit.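

Compound 2 and compound 4 both stand at a limit of this assay and not at a number, so no step from one to the other can be read: the limit of > 100000 nM in this assay, at which 2 of the 4 values shown sit.

The compounds shown leave open whether chloro in place of hydrogen on an aromatic carbon of the shared core changes the tolerated concentration at all.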